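A few compounds are considered here, and "the series" means these few. Any claim that something is new, unique, unknown or untested is made for them only; others in the source may bear on it.

Compound 1 `COc1ccc(-c2cnc(NC(=O)c3ccn[nH]3)n2C)cc1` was tested in a toxicity assay on THP-1 cells (Homo sapiens) for inhibition; on this read-out lower numbers stand for higher toxicity in this test and higher numbers for lower toxicity in this test. In this assay compound 1 gives only a limit, > 100000 nM. Compound 2 `Cn1c(-c2ccccc2)cnc1NC(=O)c1ccccc1Cl` likewise reaches only a limit in this assay, > 50000 nM. Compound 3 `COc1ccc(-c2cnc(NC(=O)c3cc(-c4ccccn4)n[nH]3)n2C)cc1` also stops at a limit in this assay, >= 50000 nM. Within the data shown here, the one change measured here is a step that the two limits leave unreadable from compound 1 to compound 3, which the two limits leave unreadable; what the three values do show is that none of compound 1, compound 2 or compound 3 harmed the cells within the tested range (the limit of > 100000 nM in this assay, at which 1 of the 3 values shown sits, (the limit of > 50000 nM in this assay, at which 1 of the 3 values shown sits), (the limit of >= 50000 nM in this assay, at which 1 of the 3 values shown sits)). Compound 4 `COc1ccc(-c2cnc(NC(=O)c3ccc(C#N)cc3)n2C)cc1` has not yet been measured. It differs from compound 1 by 4-cyanophenyl in place of 1H-pyrazol-5-yl on a carbonyl carbon. Among the measured compounds shown here, no measured step carries this same exchange, and the single step that exists has no readable size, so the data give no guide to a direction. For the measured compounds named here, the three limits point to low toxicity across compound 1, compound 2 and compound 3, a thin base of only three compounds. The step is expected to be a number no higher from compound 1 to compound 4 (the limit leaves the size open), within the scatter. Compound 4 is therefore expected to give 100000 nM in this assay, with a range from 30000 nM to 300000 nM, and most likely another limit.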

Compound 4, half-maximal cytotoxic concentration: > 100000 nM
Compound 4 gave a limit, no number; the forecaster's own chance of this, stated with the estimate: 80%; the middle value lies on the limit itself.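

In this assay compound 4 gives > 100000 nM, which is a limit and not a number. Among these compounds, compound 1 also stops at a limit, so no step between compound 1 and compound 4 can be read. The compounds shown leave open at what concentration, if any, compound 1, compound 2, compound 3 or compound 4 would harm these cells.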